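Changing the aryl group on the ring amine nitrogen

This account rests on a few compounds, and the source may have more. Where it says the series, first, only, none or still open, it means among the compounds named here.

Of the compounds shown here, three sharing one core have been measured in a functional assay on CHO cells with adenosine receptor A1 (Homo sapiens) as the target, read by cAMP accumulation and immunoassay, with a stated time of 6 min, tested at 0.01 uM; a lower number here means a stronger effect, a higher number a weaker effect of the compound at the concentration tested. Compound 1 `Nc1scc(CN2CCN(c3cccc(Cl)c3Cl)CC2)c1C(=O)c1ccc(Cl)cc1` gives 1%, compound 2 `Nc1scc(CN2CCN(c3ccc(F)cc3F)CC2)c1C(=O)c1ccc(Cl)cc1` gives 0%, and compound 3 `Nc1scc(CN2CCN(c3c(F)cccc3F)CC2)c1C(=O)c1ccc(Cl)cc1` gives -12%, the lowest of the three. The steps of a number 13 percentage points lower from compound 1 to compound 3 (beyond the scatter) and a number 12 percentage points lower from compound 2 to compound 3 (beyond the scatter) are both modest, while a number 1 percentage points lower from compound 1 to compound 2 (within the scatter) lies within the scatter. Compound 4 `Nc1scc(CN2CCN(c3ccc(F)c(Cl)c3)CC2)c1C(=O)c1ccc(Cl)cc1` differs from compound 3 by 3-chloro-4-fluorophenyl in place of 2,6-difluorophenyl on an amine nitrogen in a ring. Both steps that led into the 2,6-difluorophenyl group, from compound 1 and from compound 2, lowered the number modestly, so leaving that group for another aryl group is expected to raise the number by a similar amount, back toward the values of compound 1 and compound 2. Compound 4 is therefore estimated at 0%, within -12% to 12%, which would be an expected step of a number 12 percentage points higher from compound 3 to compound 4 (beyond the scatter).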

Compound 4, a percentage reported as activity, at one concentration (the size of the read-out at that concentration, not a potency): 4.2%
Estimate against measurement, compound 4: 4.2 percentage points below, within the range that was stated.
By their numbers in this assay, from the lowest: compound 3; then compounds 2, 1 and 4 (each within the scatter of the next).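

In this assay, 3-chloro-4-fluorophenyl gives a number 16.2 percentage points higher from compound 3 to compound 4 (beyond the scatter) and also a number 4.2 percentage points higher from compound 2 to compound 4 (within the scatter) and a number 3.2 percentage points higher from compound 1 to compound 4 (within the scatter), so the group carrying both chlorine and fluorine sits with the 2,3-dichlorophenyl and 2,4-difluorophenyl groups. Among these four compounds, only compound 3, with its 2,6-difluorophenyl group, stands apart from the rest. No measurement offered here accounts for that difference.

From the compounds shown here alone, whether a methoxy group or a nitrile on the phenyl ring would fall with compound 3 or with the others remains open. So does the outcome of replacing the aryl group with an alkyl chain.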